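Three Limits at the Top of the Range, One More Expected

The compounds below may be only part of what the source reports. "The series", "measured", "known", "first", "only" and "open" are said of these compounds alone.

Measured so far:
Compound 1 `COc1cc(-c2cc(/C=C/C(=O)c3ccc(N)cc3)[nH]n2)cc(OC)c1OC`: in a functional assay on K562 cells (Homo sapiens) for inhibition, read by sulforhodamine B assay, with a stated time of 48 h (on this read-out higher numbers stand for lower toxicity in this test and lower numbers for higher toxicity in this test), compound 1 gives only a limit of the assay, > 100000 nM.
Compound 2 `COc1ccc(C(=O)/C=C/c2cc(-c3cc(OC)c(OC)c(OC)c3)n[nH]2)cc1OC`: in this assay compound 2 gives only a limit of the assay, > 100000 nM.
Compound 3 `COc1ccc(C(=O)/C=C/c2cc(-c3cc(OC)c(OC)c(OC)c3)n[nH]2)cc1`: in this assay compound 3 gives only a limit of the assay, > 100000 nM.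

All three values sit at the limit of > 100000 nM in this assay, at which 3 of the 3 values shown sit. The three steps between the measured compounds therefore cannot be sized: a step that the two limits leave unreadable from compound 1 to compound 2, a step that the two limits leave unreadable from compound 1 to compound 3 and a step that the two limits leave unreadable from compound 2 to compound 3.

Compound 4 `COc1ccc(-c2cc(/C=C/C(=O)c3ccc(N)cc3)[nH]n2)cc1OC` is the one still to be measured. It differs from compound 1 as hydrogen in place of methoxy on an aromatic carbon. The same kind of change separates compound 2 from compound 3: hydrogen in place of methoxy on an aromatic carbon. Around the place the two differ in one respect: in compound 1 the aromatic carbon is also meta to a methoxy group (2 heavy atoms), which is not so in compound 2. The cores of the two pairs differ as 4-aminophenyl in place of 3,4-dimethoxyphenyl on a carbonyl carbon.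

Because the step from compound 2 to compound 3 is printed as a step that the two limits leave unreadable from compound 2 to compound 3, it gives no size that can be carried over. The expectation rests instead on all three measured values standing at the limit of > 100000 nM in this assay, at which 3 of the 3 values shown sit. In this assay the step is therefore expected to be a step that the limit leaves unreadable from compound 1 to compound 4. Compound 4 is estimated at 150000 nM, with the expected range running from 60000 nM to 400000 nM, and most likely it will again return only a limit.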

Compound 4, concentration lethal to 50% of the cells: > 100000 nM
Compound 4: a limit, no number; the forecaster's own chance of this, stated with the estimate: 85%; the middle value lies beyond the limit too.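

In this assay compound 4 gives > 100000 nM, which is a limit of the assay and not a number. Among these compounds, compound 1 and compound 4 thus yield no new readable step, and the values shown all stand at one limit: the limit of > 100000 nM in this assay, at which 4 of the 4 values shown sit. The compounds shown leave open whether replacing methoxy with hydrogen, or any other change among compounds 1 to 4, alters the result in this assay at all.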